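This account rests on a few compounds, and the source may have more. Where it says the series, first, only, none or still open, it means among the compounds named here.

Compound 1 `Nc1nc(-c2ccco2)nc2sc(CNC3CC3)cc12` gives the lowest of the two numbers available in an assay on CHO-K1 cells for antagonist activity at adenosine receptor A1 (Homo sapiens), read by a beta-galactosidase reporter, with stated times of 15 min and 6 h (on this read-out higher numbers stand for weaker inhibition and lower numbers for stronger inhibition), with compound 1 giving 1890 nM, while compound 2 `Cc1ccc(-c2nc(N)c3cc(CN4CCc5ccccc5C4)sc3n2)o1` gives 3320 nM in this assay, a gap that lies within the scatter. Compound 3 `Nc1nc(-c2ccco2)nc2sc(CN3CCC(F)(F)CC3)cc12` differs from compound 1 by 4,4-difluoropiperidin-1-yl in place of cyclopropylamino on a saturated chain carbon bound to an aromatic carbon. Among the compounds with values here, no measured pair shows the effect of such a change, so the step from compound 1 to compound 3 is expected to be a 1.3-fold higher number from compound 1 to compound 3 (0.12 log units; within the scatter), no larger than the scatter in either direction. Compound 3 is therefore estimated at 2500 nM in this assay, between 800 nM and 8000 nM.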

Compound 3, inhibition constant: 2230 nM
For compound 3 the middle estimate is 1.1-fold (0.05 log units) above the measured one; low and high end bracket the measured number.
By their numbers in this assay, from the lowest: compounds 1, 3 and 2 (each within the scatter of the next).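

In this assay, within the data shown here, 4,4-difluoropiperidin-1-yl in place of cyclopropylamino on a saturated chain carbon bound to an aromatic carbon gives a 1.2-fold higher number from compound 1 to compound 3 (0.07 log units; within the scatter), the first step that can be read at this place. The entering group has 8 heavy atoms where the leaving one has 4, and 0 hydrogen-bond donors where that one has 1, yet the step stays within the scatter. No available evidence bears on this result.

From the compounds shown here alone, whether a carboxylic acid or a longer chain at this place would give a step beyond the scatter remains open. Compound 2 differs from compound 1 and compound 3 in more than one place, so the effect of its groups cannot be read.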